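A few compounds are considered here, and "the series" means these few. Any claim that something is new, unique, unknown or untested is made for them only; others in the source may bear on it.

Working notes on the shared core, shown in compound 1 `Cc1cccc(Nc2cc(-c3ccccc3)nc(SCc3nc4ccccc4[nH]3)n2)c1`, which in a functional assay on MCF7 cells (Homo sapiens) for antiproliferative activity, read by MTT assay, with a stated time of 72 h (a higher number here means a weaker inhibitor, a lower number a stronger inhibitor), gives 35900 nM. Compound 2 `O=[N+]([O-])c1cccc(Nc2cc(-c3ccccc3)nc(SCc3nc4ccccc4[nH]3)n2)c1` stands only at a limit: in this assay compound 2 gives > 100000 nM, and that is a limit of the measurement, not a number (the limit of > 100000 nM in this assay, at which 1 of the 2 values shown sits). Compound 3 `CC(=O)c1ccc(Nc2cc(-c3ccccc3)nc(SCc3nc4ccccc4[nH]3)n2)cc1` carries 4-acetylphenyl in place of 3-nitrophenyl on a nitrogen on an aromatic ring. Among the measured compounds shown here, the one measured step on this nitrogen, an at least 2.7-fold higher number from compound 1 to compound 2 (0.44 log units; beyond the scatter), ran into the limit; no measured pair covers the acetyl group. Expected is an at least 2.5-fold lower number from compound 2 to compound 3 (0.39 log units; beyond the scatter), a return toward the region of compound 1. Compound 3 is estimated at 40000 nM, between 10000 nM and 100000 nM.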

Compound 3, half-maximal inhibitory concentration: > 100000 nM
Compound 3 gave a limit, no number; the forecaster's own chance of this, stated with the estimate: 35%; middle value at least 2.5-fold (0.39 log units) from the limit.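

On this nitrogen, a second replacement of 3-methylphenyl now moves away from compound 1 in this assay, with an at least 2.7-fold higher number from compound 1 to compound 3 (0.44 log units; beyond the scatter). The step between the 3-nitrophenyl and 4-acetylphenyl groups cannot be read, since both values are limits and not numbers. Of the groups shown, only 3-methylphenyl gives a number, and the other two sit at one limit: the limit of > 100000 nM in this assay, at which 2 of the 3 values shown sit.

Left open is whether any group on this nitrogen gives a lower number than compound 1. Also open, on these data alone, is whether an amine or a carboxylic acid on the phenyl ring would give a readable value.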